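This account rests on a few compounds, and the source may have more. Where it says the series, first, only, none or still open, it means among the compounds named here.

Measured compounds:
compound 1 `O=c1c(S(=O)(=O)c2ccc(F)cc2F)cc2cnc(Nc3ccc4[nH]ccc4c3)nc2n1C1CC1` — 500 nM
compound 2 `O=c1[nH]c2nc(Nc3ccc4[nH]ccc4c3)ncc2cc1S(=O)(=O)c1ccc(F)cc1F` — 15000 nM

In a functional assay on K562 cells (Homo sapiens) for inhibition, read by trypan blue exclusion, with a stated time of 72 h (on this read-out lower numbers stand for stronger inhibition and higher numbers for weaker inhibition), compound 2 gives the highest of the two numbers; its nearest neighbour is compound 1, and the step of a 30-fold higher number from compound 1 to compound 2 (1.48 log units; beyond the scatter) is the only one on record. Compound 3 `O=c1c(S(=O)(=O)c2ccc(F)cc2F)cc2cnc(Nc3ccc4[nH]ccc4c3)nc2n1C1CCCCC1` differs from compound 2 by cyclohexyl in place of hydrogen on an aromatic nitrogen. Within the data shown here, the one step that bears on this change is the reverse of a 30-fold higher number from compound 1 to compound 2 (1.48 log units; beyond the scatter), where removing the cyclopropyl from that aromatic nitrogen raised the number by a large margin; putting a cyclohexyl in the same place is expected to move the number back down in this assay, though cyclohexyl is not cyclopropyl and the size of the drop is uncertain. For compound 3 the expected step is a 10-fold lower number from compound 2 to compound 3 (1.00 log units; beyond the scatter). Compound 3 is thus estimated at 1500 nM, with a range from 300 nM to 8000 nM.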

Compound 3, half-maximal inhibitory concentration: 10000 nM
Estimate against measurement, compound 3: 6.7-fold (0.82 log units) below, and the stated range ends below it.
By their numbers in this assay, from the lowest: compound 1; then compounds 3 and 2 (each within the scatter of the next).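

Putting a group on the aromatic nitrogen does not by itself give the lower number of compound 1: in this assay cyclohexyl in place of hydrogen gives a 1.5-fold lower number from compound 2 to compound 3 (0.18 log units; within the scatter), which leaves compound 3 level with the unsubstituted compound 2. Exchanging cyclopropyl for cyclohexyl gives a 20-fold higher number from compound 1 to compound 3 (1.30 log units; beyond the scatter), so the identity of the group at this position matters, and among these compounds only the cyclopropyl of compound 1 stands apart. Nothing available accounts for the difference between these two rings.

From the compounds shown here alone, whether a methyl, an isopropyl, a cyclobutyl or a cyclopentyl on the same nitrogen would track compound 1 or compound 3 remains open. Also open, going by these compounds, is whether the same order holds when another group replaces the (2,4-difluorophenyl)sulfonyl group.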